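The source may hold more compounds than are shown below. What is called first, only, known or untested is meant among the compounds shown, and "the series" means these compounds.

Of the compounds shown here, two have so far been tested in an assay on BTI cells for inhibition of Amine oxidase [flavin-containing] B (Homo sapiens), read by fluorescence, with stated times of 30 min and 1 h, tested at 1 uM; on this read-out higher numbers stand for more inhibition at the one concentration tested (going by the name of the read-out) and lower numbers for less inhibition. Compound 1 `C[C@H](NCc1ccc(OCCCCN2CCN(c3cccc4c3ccn4S(=O)(=O)c3ccccc3)CC2)cc1)C(N)=O` gives 20%, while compound 2 `C#CCN(C)Cc1ccc(OCCCCN2CCN(c3cccc4c3ccn4Cc3cccc(Cl)c3)CC2)cc1` gives 85%, the higher of the two numbers, with a gap to compound 1 that lies beyond the usual scatter. These two differ in more than one place, so the share of each part of the structure in that gap cannot be read off directly. Compound 3 `C#CCN(C)Cc1ccc(OCCCCN2CCN(c3cccc4c3ccn4S(=O)(=O)c3ccccc3)CC2)cc1` keeps the rest of compound 2 unchanged and takes over the group that compound 1 carries: phenylsulfonyl in place of 3-chlorobenzyl on an aromatic nitrogen. For the measured compounds named here, no measured pair isolates this change. Because compound 1 gives 20% with the same phenylsulfonyl group in place, a drop beyond the scatter is expected in this assay, though smaller than the whole gap. The expected step is estimated as a number 23 percentage points lower from compound 2 to compound 3 (beyond the scatter). Compound 3 is therefore expected to give about 62%, within a range of 35% to 88%.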

Compound 3, a percentage reported as inhibition, at one concentration (the size of the read-out at that concentration, not a potency): 51%
Beside the measured number, compound 3's estimate is 11 percentage points above it; the range from low to high includes it.
By their numbers in this assay, from the lowest: compound 1; then compound 3; then compound 2.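

In this assay, two single changes can now be read on their own. On an aromatic nitrogen, phenylsulfonyl in place of 3-chlorobenzyl gives a number 34 percentage points lower from compound 2 to compound 3 (beyond the scatter) and shows that the group at this position matters even with the methyl(propargyl)amino group held fixed, while on a saturated chain carbon bound to an aromatic carbon, methyl(propargyl)amino in place of (1-carbamoylethyl)amino gives a number 31 percentage points higher from compound 1 to compound 3 (beyond the scatter) with phenylsulfonyl held fixed. Nothing available gives a reason for either step.

From the compounds shown here alone, it remains open how a plain benzyl group or a small methyl group on the aromatic nitrogen would compare with these two groups. Going by these compounds, it is also open whether the nitrogen step would keep its size with (1-carbamoylethyl)amino on the chain carbon.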